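The source may hold more compounds than are shown below. What is called first, only, known or untested is meant among the compounds shown, and "the series" means these compounds.

Compound 1 `CCCCCCOc1ccc2c(Cl)ccnc2c1` was tested in a functional assay on NCI-H1650 cells (Homo sapiens) for cytotoxicity, read by MTT assay, with a stated time of 48 h (a lower number here means a stronger inhibitor, a higher number a weaker inhibitor), where compound 1 gives 2080 nM. Among the three compounds measured so far it holds the second highest number. Compound 2 `CC(C)COc1ccc2c(Cl)ccnc2c1`, which differs from it only in the chain on the ring oxygen, gives 2100 nM; the step between them is a 1.0-fold higher number from compound 1 to compound 2 (0.00 log units; within the scatter), so the two cannot be told apart here. Compound 3 `CCCCCCOc1ccc2c(NCCN(C)C)ccnc2c1`, which keeps the same chain but carries another group in place of the chloro, gives 930 nM; that step is a 2.2-fold lower number from compound 1 to compound 3 (0.35 log units; beyond the scatter), a modest gain.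

The next compound, compound 4 `CCCCCCCCOc1ccc2c(Cl)ccnc2c1`, differs from compound 1 in the chain alone: ethyl in place of hydrogen on a saturated chain carbon, six bonds along the chain from an oxygen on an aromatic ring. Among the compounds with values here, the only measured step that touches this chain is a 1.0-fold higher number from compound 1 to compound 2 (0.00 log units; within the scatter), which stayed within the scatter, while the change at the chloro group does not bear on this comparison. Altering the chain is therefore expected to leave this assay largely unmoved, and the expected step is a 1.0-fold lower number from compound 1 to compound 4 (0.02 log units; within the scatter). Compound 4 is estimated at 2000 nM, most likely between 1000 nM and 4200 nM.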

Compound 4, half-maximal inhibitory concentration: 3240 nM
Compound 4: the middle estimate sits 1.6-fold (0.21 log units) below what was measured; measured number inside the range.
By their numbers in this assay, from the lowest: compound 3; then compounds 1, 2 and 4 (each within the scatter of the next).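

In this assay ethyl in place of hydrogen on a saturated chain carbon, six bonds along the chain from an oxygen on an aromatic ring, gives a 1.6-fold higher number from compound 1 to compound 4 (0.19 log units; within the scatter) and so adds a second chain change that stays inside the scatter. Together with isopropyl in place of pentyl in compound 2, this means that neither chain change among these compounds gives a step beyond the scatter, while the only such step shown is still the one at the chloro group. No measurement here explains why these chain changes leave the number within the scatter.

On these data alone, it remains open whether the same chain change would also stay within the scatter with the (2-(dimethylamino)ethyl)amino group of compound 3 in place of chloro. Also open, as far as these compounds go, is whether an amine or a carboxylic acid at the end of the chain, or a much longer chain, would move the number beyond the scatter.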